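The source may hold more compounds than are shown below. What is called first, only, known or untested is meant among the compounds shown, and "the series" means these compounds.

Measured compounds:
- compound 1 `Cc1cccc(N(C)CCCN2CCN(c3ccccc3)CC2)c1`: 84.8 nM
- compound 2 `Oc1cccc(NCCCN2CCN(c3ccccc3)CC2)c1`: 10.1 nM
- compound 3 `CN(CCCN1CCN(c2ccccc2)CC1)c1cccc(O)c1`: 20 nM

In an assay on HEK293 cells for displacement of a labelled ligand from 5-hydroxytryptamine receptor 7 (Homo sapiens), read by scintillation counting, with a stated time of 30 min (on this read-out higher numbers stand for weaker inhibition and lower numbers for stronger inhibition), compound 3 stands second highest of the three numbers; the nearest is compound 2, the step of a 2.0-fold higher number from compound 2 to compound 3 (0.30 log units; within the scatter) lying within the scatter, while the step of a 4.2-fold lower number from compound 1 to compound 3 (0.63 log units; beyond the scatter) is beyond it. Compound 4 `CCCN(CCCN1CCN(c2ccccc2)CC1)c1cccc(O)c1` differs from compound 3 by ethyl in place of hydrogen on a saturated chain carbon bound to a nitrogen on an aromatic ring. Going by the values given here, the only step that bears on this is that from compound 2 to compound 3, where methyl in place of hydrogen on the aromatic nitrogen gave a 2.0-fold higher number from compound 2 to compound 3 (0.30 log units; within the scatter). Lengthening the chain further has no direct precedent here; a small step toward a higher number, within the scatter, is expected for compound 4, a 1.5-fold higher number from compound 3 to compound 4 (0.18 log units; within the scatter). Compound 4 is therefore estimated at 30 nM, with a range of 10 nM to 90 nM.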

Compound 4, inhibition constant: 20.8 nM
Estimate against measurement, compound 4: 1.4-fold (0.16 log units) above; the range from low to high includes it.
By their numbers in this assay, from the lowest: compounds 2, 3 and 4 (each within the scatter of the next, the first and the last beyond it); then compound 1.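

In this assay, ethyl in place of hydrogen on a saturated chain carbon bound to a nitrogen on an aromatic ring gives a 1.0-fold higher number from compound 3 to compound 4 (0.02 log units; within the scatter), so extending methyl to propyl leaves the number within the scatter. Propyl in place of hydrogen on that nitrogen gives a 2.1-fold higher number from compound 2 to compound 4 (0.31 log units; beyond the scatter), a modest step just beyond the scatter. No evidence is available to explain this result.

Going by these compounds, whether a butyl chain, a longer chain or a carboxylic acid at the end of the chain would leave the number unchanged stays open. The compounds shown also leave open how a cyclopropyl ring on that nitrogen would compare.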